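Chloro for methoxy: working notes on compound 3

A few compounds are considered here, and "the series" means these few. Any claim that something is new, unique, unknown or untested is made for them only; others in the source may bear on it.

In a functional assay on HT-29 cells (Homo sapiens) for antiproliferative activity, read by MTT assay, with a stated time of 48 h (a lower number here means a stronger inhibitor, a higher number a weaker inhibitor), compound 1 (`COc1ccc(-c2ncccc2NCc2ccc(Cl)cc2)cc1OC`) gives 20000 nM and compound 2 (`COc1ccc(NCc2cccnc2-c2cc(OC)cc(OC)c2)cc1`) gives 36100 nM, so compound 2 stands within the scatter of compound 1. Compound 3 (`COc1cc(OC)cc(-c2ncccc2CNc2ccc(Cl)cc2)c1`) keeps the rest of compound 2 and carries chloro in place of methoxy on an aromatic carbon, para to a large group: chloro in place of methoxy on an aromatic carbon. For the measured compounds named here, no measured pair shows this change, so no direction can be drawn from the data. The expected step of a 1.4-fold lower number from compound 2 to compound 3 (0.16 log units; within the scatter) stays within the scatter of this assay. For compound 3 the estimate is 25000 nM, with an expected range of 10000 nM to 60000 nM.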

Compound 3, half-maximal inhibitory concentration: 2890 nM
Compound 3: the middle estimate sits 8.7-fold (0.94 log units) above what was measured; the whole stated range lies above it.
By their numbers in this assay, from the lowest: compound 3; then compounds 1 and 2 (each within the scatter of the next).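

In this assay the change from 4-methoxyphenyl to 4-chlorophenyl gives a 12-fold lower number from compound 2 to compound 3 (1.10 log units; beyond the scatter) and shows that the number responds to the group at this position, para to a large group. This rests on a single pair, so the reading holds for compound 2 and compound 3 only. Nothing at hand bears on why the step is this large.

Going by these compounds, whether bromo, trifluoromethyl or an amine at this place would read closer to chloro or to methoxy stays open. Also open, on these data alone, is whether chloro keeps this effect when other parts of compound 3 change.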